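Methyl to methoxy on the acid-bearing ring: series notes

This account rests on a few compounds, and the source may have more. Where it says the series, first, only, none or still open, it means among the compounds named here.

Measured so far:
compound 1, `COc1cc(C(=O)O)ccc1OCCCCOc1ccc(C(=O)C(C)C)c(O)c1C`: 25.6%
compound 2, `Cc1cc(C(=O)O)ccc1OCCCCOc1ccc(C(=O)CC(C)C)c(O)c1C`: 42.1%

In an assay on HEK293 cells for positive allosteric modulation of metabotropic glutamate receptor 3 (Rattus norvegicus), read by thallium flux, with a stated time of 2.5 min (on this read-out lower numbers stand for smaller maximal responses and higher numbers for larger maximal responses), compound 2 gives 42.1% and stands highest of the two numbers measured. Its nearest neighbour is compound 1, which in this assay gives 25.6%, a gap beyond the usual scatter. Going by the values given here, compound 1 and compound 2 differ in two places at once, so no single step between them can be read off; only the two values themselves are known.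

Compound 3, `COc1cc(C(=O)O)ccc1OCCCCOc1ccc(C(=O)CC(C)C)c(O)c1C`, has not yet been measured. Relative to compound 2 the change is methoxy in place of methyl on an aromatic carbon.

Among the compounds with values here, no step for this change is available among the measured pairs. Within the data shown here, the only pointer is that compound 1, which carries the methoxy group, sits lower with 25.6%, but it also carries a different ketone side chain, so that number cannot be attributed to the methoxy group alone. A modest decrease, near the edge of the scatter, is expected: the step of a number 9.1 percentage points lower from compound 2 to compound 3 (within the scatter) is the estimate. For compound 3 in this assay the expected value is 33%, with a range from 18% to 48%.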

Compound 3, largest response reached (reported as percent of maximum), in percent of the reference or control that the assay uses: 73.9%
The estimate for compound 3 lay 40.9 percentage points below the measured number; measured number above the stated range.
By their numbers in this assay, from the lowest: compound 1; then compound 2; then compound 3.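

In this assay, this position on an aromatic carbon, ortho to a large group and meta to a carboxy group, now has its first single-place reading: with isobutyl held on the carbonyl carbon, methoxy in place of methyl gives a number 31.8 percentage points higher from compound 2 to compound 3 (beyond the scatter). The ketone side chain also has its first such reading: with methoxy held on the acid-bearing ring, isobutyl in place of isopropyl gives a number 48.3 percentage points higher from compound 1 to compound 3 (beyond the scatter), so each of these two changes, read against compound 3, gives a large rise. No measurement accounts for either step.

As far as these compounds go, each step is read only with the other change already in place, so it stays open whether methoxy would give a similar rise with isopropyl on the carbonyl carbon, or isobutyl a similar rise with methyl on the ring. The compounds shown also leave open how an ethoxy group or a chlorine atom would compare at this aromatic carbon, and whether a longer chain than isobutyl on the carbonyl carbon would raise the number further.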